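Arylamine to azetidine on the quinone carbon of the core

The compounds below may be only part of what the source reports. "The series", "measured", "known", "first", "only" and "open" are said of these compounds alone.

Three measured members share one core, differing only in the group on the double-bonded ring carbon. Compound 1 `Cc1ccc(NC2=CC(=O)c3nc4n(c3C2=O)[C@H]2OC[C@@H](O)[C@H]2OC4)cc1` carries 4-methylphenyl on the amine nitrogen and in a functional assay on MCF7 cells (Homo sapiens) for inhibition, read by sulforhodamine B assay (on this read-out lower numbers stand for stronger inhibition and higher numbers for weaker inhibition), compound 1 gives 1660 nM. Compound 2 `COc1cccc(NC2=CC(=O)c3nc4n(c3C2=O)[C@H]2OC[C@@H](O)[C@H]2OC4)c1` carries 3-methoxyphenyl there; in this assay compound 2 reaches only the limit > 4000 nM, which is a limit of the assay and not a number. Compound 3 `COc1ccc(NC2=CC(=O)c3nc4n(c3C2=O)[C@H]2OC[C@@H](O)[C@H]2OC4)cc1` carries 4-methoxyphenyl, and in this assay compound 3 gives 5420 nM. Among the two numbers compound 3 holds the highest; its nearest neighbour is compound 1, with a 3.3-fold higher number from compound 1 to compound 3 (0.51 log units; beyond the scatter). The step of an at least 2.4-fold higher number from compound 1 to compound 2 (0.38 log units; beyond the scatter) points the same way, while a step that the limit leaves unreadable from compound 2 to compound 3 because of the limit of > 4000 nM in this assay, at which 1 of the 3 values shown sits.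

Compound 4 `O=C1C=C(N2CCC2)C(=O)c2c1nc1n2[C@H]2OC[C@@H](O)[C@H]2OC1` departs further: azetidin-1-yl in place of (4-methoxyphenyl)amino on a double-bonded ring carbon. For the measured compounds named here, none of the measured steps bears on this change, since all three vary the aromatic ring while keeping the arylamine. The expectation therefore rests on compound 3 alone, with wide uncertainty; the expected step is a 1.2-fold lower number from compound 3 to compound 4 (0.08 log units; within the scatter), with no direction claimed beyond the scatter. For compound 4 in this assay the estimate is 4500 nM, expected to fall between 1200 nM and 17000 nM.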

Compound 4, half-maximal inhibitory concentration: > 16000 nM
Compound 4: only a limit was reported; the forecaster's own chance of this, stated with the estimate: 35%; at least 3.5-fold (0.55 log units) between middle value and limit.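

For the compounds shown here, compound 4 is the first change here that removes the aromatic ring from this position rather than varying it, and in this assay compound 4 reaches only > 16000 nM, which is a limit of the assay and not a number. Two steps can still be read, an at least 2.9-fold higher number from compound 3 to compound 4 (0.47 log units; beyond the scatter) and an at least 9.6-fold higher number from compound 1 to compound 4 (0.98 log units; beyond the scatter), so on the shared core azetidin-1-yl gives weaker inhibition than either (4-methoxyphenyl)amino or (4-methylphenyl)amino on the double-bonded ring carbon. The step between compound 2 and compound 4 cannot be read, because both values are limits, the one for compound 4 being: the limit of > 16000 nM in this assay, at which 1 of the 4 values shown sits.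

The swap changes several things at once, so the compounds shown do not tell whether the weaker inhibition follows from losing the aromatic ring, from losing the hydrogen on the amine nitrogen, or from the four-membered ring itself. A cyclohexylamino group would keep that hydrogen without the aromatic ring, while an N-methyl-N-phenylamino group would keep the aromatic ring without it, and a piperidin-1-yl group would test a larger ring in place of azetidin-1-yl.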